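The compounds below may be only part of what the source reports. "The series", "measured", "known", "first", "only" and "open" are said of these compounds alone.

In a functional assay on HepG2 cells (Homo sapiens) for inhibition, read by MTT assay (on this read-out lower numbers stand for stronger inhibition of growth and higher numbers for weaker inhibition of growth), compound 1 `COc1cc2oc(-c3cccc(NC(=O)c4cccc(Br)c4)c3)cc(=O)c2c(OC)c1OC` gives 10900 nM, compound 2 `COc1cc2oc(-c3cccc(NC(=O)c4ccc(F)cc4)c3)cc(=O)c2c(OC)c1OC` gives 47200 nM and compound 3 `COc1cc2oc(-c3cccc(NC(=O)c4cccc(Br)c4)c3)cc(=O)c2c(O)c1OC` gives 44800 nM. Compound 3 thus stands level with compound 2 within the scatter and apart from compound 1, a 4.1-fold higher number from compound 1 to compound 3 (0.61 log units; beyond the scatter). Compound 4 `COc1ccccc1C(=O)Nc1cccc(-c2cc(=O)c3c(O)c(OC)c(OC)cc3o2)c1` differs from compound 3 in one place: 2-methoxyphenyl in place of 3-bromophenyl on a carbonyl carbon. For the measured compounds named here, the closest precedent is the exchange of the same 3-bromophenyl on a carbonyl carbon for 4-fluorophenyl, a 4.3-fold higher number from compound 1 to compound 2 (0.64 log units; beyond the scatter). That step was modest, but it brought in a different group and started from compound 1, so only a small rise in this assay is expected, possibly within the scatter. The expected step is a 1.3-fold higher number from compound 3 to compound 4 (0.13 log units; within the scatter). For compound 4 the estimated value is 60000 nM, with an expected range of 25000 nM to 140000 nM.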

Compound 4, concentration for 50% growth inhibition: > 100000 nM
Compound 4: only a limit was reported (the forecaster's own chance of this, stated with the estimate: 15%); middle value at least 1.6-fold (0.22 log units) away from the limit.
By their numbers in this assay, from the lowest: compound 1; then compounds 3 and 2 (each within the scatter of the next). At a limit, above all of these: compound 4.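

In this assay compound 4 gives > 100000 nM, which is a limit of the assay and not a number. With the core of compound 3 kept, 2-methoxyphenyl in place of 3-bromophenyl on the carbonyl carbon gives an at least 2.2-fold higher number from compound 3 to compound 4 (0.34 log units; beyond the scatter), so this position also moves the read-out on a second core, not only on that of compound 1. Both exchanges of 3-bromophenyl shown so far raise the number, though the limit hides the full size of this step.

As far as these compounds go, it stays open whether 2-methoxyphenyl would act alike on the core of compound 1. Also open, from the compounds shown here alone, is whether an amine or a carboxylic acid in place of the bromine would keep the number of compound 1 or lower it.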